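Triazole hydrazones on breast cancer cells: a dibromo-hydroxy variant

A few compounds are considered here, and "the series" means these few. Any claim that something is new, unique, unknown or untested is made for them only; others in the source may bear on it.

Three compounds share one core, a triazole carrying a pyridyl group, a phenyl group and a sulfur-linked side arm, and were tested in a functional assay on MCF7 cells (Homo sapiens) for inhibition, read by MTT assay, with a stated time of 48 h; on this read-out lower numbers stand for stronger inhibition and higher numbers for weaker inhibition. Compound 1 `Clc1cccc(CSc2nnc(-c3ccncc3)n2-c2ccccc2)c1`, with a chlorobenzyl side arm, gives 10500 nM in this assay. In the other two the side arm is an acylhydrazone. Compound 2 `O=C(CSc1nnc(-c2ccncc2)n1-c1ccccc1)N/N=C/c1ccc(O)cc1` reaches only the limit of the assay, > 50000 nM. Compound 3 `O=C(CSc1nnc(-c2ccncc2)n1-c1ccccc1)N/N=C/c1ccc(Cl)cc1` gives 9930 nM, the lowest of the two numbers shown, though compound 1 sits within the scatter of it. Going by the values given here, the single step measured, an at least 5.0-fold lower number from compound 2 to compound 3 (0.70 log units; beyond the scatter), is the only guide available.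

Compound 4 `O=C(CSc1nnc(-c2ccncc2)n1-c1ccccc1)N/N=C/c1cc(Br)cc(Br)c1O` differs from compound 3 by 3,5-dibromo-2-hydroxyphenyl in place of 4-chlorophenyl on a carbon with a double bond to nitrogen. It brings back a hydroxy, the group that accompanied the limit in compound 2, but adds two bromines, halogens like the chloro of compound 3. As far as these compounds go, the pull of these opposing features is unknown, so the expected change is a 1.5-fold higher number from compound 3 to compound 4 (0.18 log units; within the scatter), leaning weaker. For compound 4 in this assay the estimate is 15000 nM, within 4000 nM to 60000 nM.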

Compound 4, half-maximal inhibitory concentration: 8440 nM
Estimate against measurement, compound 4: 1.8-fold (0.25 log units) above; low and high end bracket the measured number.
By their numbers in this assay, from the lowest: compounds 4, 3 and 1 (each within the scatter of the next). At a limit, above all of these: compound 2.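

In this assay, the step of a 1.2-fold lower number from compound 3 to compound 4 (0.07 log units; within the scatter) lies within the scatter, so 3,5-dibromo-2-hydroxyphenyl and 4-chlorophenyl cannot be told apart in this place on the carbon with a double bond to nitrogen. A hydroxy on this ring therefore does not always come with a weak result, as the step of an at least 5.9-fold lower number from compound 2 to compound 4 (0.77 log units; beyond the scatter) lies beyond the scatter. Compound 2 stands at a limit of the assay, not at a number, so the true size of that step is unknown: the limit of > 50000 nM in this assay, at which 1 of the 4 values shown sits.

The compounds shown cannot separate the part played by the two bromines from that of the hydroxy's placing, as both differ together between 4-hydroxyphenyl and 3,5-dibromo-2-hydroxyphenyl. As far as these compounds go, whether an amine or a methoxy group on the same ring would fit with these numbers also stays open.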